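Swapping the aryl ether on a shared acetal core

The source may report more compounds than this note shows. Statements on the series, on what has been measured and on what is new or still open speak of the compounds shown alone.

Measured in an assay for inhibition of prostacyclin synthase (Homo sapiens), using microsomes; on this read-out higher numbers stand for weaker inhibition and lower numbers for stronger inhibition:
compound 1 `CC(C)(Oc1ccccc1)C1OCC(C/C=C\CCC(=O)O)C(c2cccnc2)O1` gives 75000 nM
compound 2 `Cc1ccc(OC(C)(C)C2OCC(C/C=C\CCC(=O)O)C(c3cccnc3)O2)cc1` gives 25000 nM
compound 3 `CSc1ccccc1OC(C)(C)C1OCC(C/C=C\CCC(=O)O)C(c2cccnc2)O1` gives > 100000 nM, which is a limit of the assay and not a number

Compound 3 therefore stands at the weak end of the shown range: the assay records only a bound for it (the limit of > 100000 nM in this assay, at which 1 of the 3 values shown sits), so its true number is not known. Among the three, two steps are informative. Adding a methyl to the aromatic ring gave a 3.0-fold lower number from compound 1 to compound 2 (0.48 log units; beyond the scatter), while adding a methylsulfanyl gave an at least 1.3-fold higher number from compound 1 to compound 3 (0.12 log units; that floor lies within the scatter), which lies within the scatter. The direct aryl swap gave an at least 4.0-fold higher number from compound 2 to compound 3 (0.60 log units; beyond the scatter).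

Compound 4 `COc1ccc(OC(C)(C)C2OCC(C/C=C\CCC(=O)O)C(c3cccnc3)O2)c([N+](=O)[O-])c1` differs from compound 3 by 4-methoxy-2-nitrophenyl in place of 2-(methylsulfanyl)phenyl on an oxygen on a saturated carbon. Among the measured compounds shown here, the step from compound 2 to compound 3 is the closest precedent, since it too exchanges one substituted aryl group for another on the same oxygen, and it moved the number at least modestly. The single-substituent steps from compound 1 were within or just beyond the scatter. Because compound 3 already sits at the limit (the limit of > 100000 nM in this assay, at which 1 of the 3 values shown sits), any further weakening would leave compound 4 also at a limit. Compound 4 is expected to give a number no higher from compound 3 to compound 4 (the limit leaves the size open), with a fair chance of another limit. The estimate for compound 4 is 100000 nM, ranging from 30000 nM to 300000 nM.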

Compound 4, half-maximal inhibitory concentration: 23000 nM
Compound 4: the middle estimate sits 4.3-fold (0.64 log units) above what was measured; measured number outside the range, below it.
By their numbers in this assay, from the lowest: compounds 4 and 2 (each within the scatter of the next); then compound 1. At a limit, above all of these: compound 3.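

The swap to 4-methoxy-2-nitrophenyl, which brings more heavy atoms and more hydrogen-bond acceptors than the 2-(methylsulfanyl)phenyl it replaces, gave an at least 4.3-fold lower number from compound 3 to compound 4 (0.63 log units; beyond the scatter), so a substituted aryl group on this oxygen need not leave a compound at the weak end of the range. Against the plain phenyl of compound 1, the same group gave a 3.3-fold lower number from compound 1 to compound 4 (0.51 log units; beyond the scatter), while against the 4-methylphenyl of compound 2 it gave a 1.1-fold lower number from compound 2 to compound 4 (0.04 log units; within the scatter), so these two differently substituted rings cannot be told apart in this assay. The reading for compound 3 remains a limit of the assay and not a number, so the full size of its step stays unknown: the limit of > 100000 nM in this assay, at which 1 of the 4 values shown sits.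

The compounds shown leave open whether the nitro or the methoxy group alone would give a number like that of compound 4. They also leave open whether an amine or a carboxylic acid on this aryl ring would bring the number lower than the values seen so far.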